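This account rests on a few compounds, and the source may have more. Where it says the series, first, only, none or still open, it means among the compounds named here.

Compound 2 `CC(C)NC(=O)c1ccc(-c2onc3ccc(C(=O)O)cc23)cc1` gives 340 nM in an assay for inhibition of inositol hexakisphosphate kinase 3 (Homo sapiens), read by colorimetric assay, coupled enzyme assay and malachite green, with a stated time of 120 min, in the presence of a further agent that is not named here; a higher number here means a weaker inhibitor, a lower number a stronger inhibitor. Within the data shown here, compound 1 `O=C(O)c1ccc2noc(-c3ccc(Oc4ccccn4)cc3)c2c1` gives 2060 nM in the same assay, and the step of a 6.1-fold lower number from compound 1 to compound 2 (0.78 log units; beyond the scatter) puts compound 2 at the lowest of the two numbers so far, with compound 1 the nearest neighbour. Compound 3 `O=C(O)c1ccc2noc(-c3ccc(NC(=O)c4ccccc4)cc3)c2c1` is the next point in the series; its change from compound 2 is benzamido in place of isopropylcarbamoyl on an aromatic carbon. Among the measured compounds shown here, the only measured step, from compound 1 to compound 2, touched the same aromatic carbon but exchanged a different pair of groups, so it bears on the new step only loosely. Both groups in the new exchange keep one hydrogen-bond donor and one hydrogen-bond acceptor, so the step is expected to be small, estimated as a 1.5-fold higher number from compound 2 to compound 3 (0.17 log units; within the scatter) and possibly within the scatter. Compound 3 is therefore expected to give about 500 nM in this assay, with a range of 150 nM to 1700 nM.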

Compound 3, half-maximal inhibitory concentration: 200 nM
For compound 3 the middle estimate is 2.5-fold (0.40 log units) above the measured one; low and high end bracket the measured number.
By their numbers in this assay, from the lowest: compounds 3 and 2 (each within the scatter of the next); then compound 1.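

In this assay this aromatic carbon, para to a large group, does not separate benzamido from isopropylcarbamoyl: a 1.7-fold lower number from compound 2 to compound 3 (0.23 log units; within the scatter) holds although the entering group adds one six-membered aromatic ring of carbon only and attaches through nitrogen rather than through the carbonyl. Measured against (pyridin-2-yl)oxy, benzamido gives a 10-fold lower number from compound 1 to compound 3 (1.01 log units; beyond the scatter) and so stands on the same side of compound 1 as isopropylcarbamoyl, making compound 1 the outlier of the three. Nothing available here accounts for either step.

The compounds shown leave open whether the amide hydrogen matters, which an N-methylbenzamido group would test, and whether a plain amine at this carbon would keep the number of compound 3. They also leave open how much further size is accepted here, for which a longer chain on the carbamoyl or a chlorobenzamido group would be informative.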